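The compounds below may be only part of what the source reports. "The series", "measured", "known", "first", "only" and "open" are said of these compounds alone.

In a functional assay (aorta) with Rattus norvegicus as the target (a lower number here means that less compound is needed, a higher number that more compound is needed for the effect), compound 1 `CNC(=N)Nc1nc(-c2ccc(OC)cc2)c(-c2ccc(OC)cc2)s1` gives 1.2 uM, compound 2 `COc1ccc(-c2nc(/N=C(\N)N(C)C)sc2-c2ccc(OC)cc2)cc1` gives 4.8 uM, and compound 3 `COc1ccc(-c2nc(/N=C(\N)N3CCOCC3)sc2-c2ccc(OC)cc2)cc1` gives 66 uM, the highest of the three numbers. Compound 4 `COc1ccc(-c2nc(CNC(=O)CSC)sc2-c2ccc(OC)cc2)cc1` differs from compound 3 on an aromatic carbon of the shared core: a group of 7 heavy atoms (4 carbon, 1 nitrogen, 1 oxygen, 1 sulfur; no ring) in place of a group of 9 heavy atoms (5 carbon, 3 nitrogen, 1 oxygen; one six-membered non-aromatic ring with 2 hetero atoms), on an aromatic carbon. All three measured steps change the group at this place: a 4.0-fold higher number from compound 1 to compound 2 (0.60 log units; beyond the scatter) is modest, while a 55-fold higher number from compound 1 to compound 3 (1.74 log units; beyond the scatter) and a 14-fold higher number from compound 2 to compound 3 (1.14 log units; beyond the scatter) are large. None of them brings in ((((methylsulfanyl)methyl)carbonyl)amino)methyl, so the precedent is only indirect. With the morpholin-4-yl ring leaving, and given a 14-fold higher number from compound 2 to compound 3 (1.14 log units; beyond the scatter), a modest move towards a lower number is expected, with wide uncertainty. The expected step in this assay is a 3.3-fold lower number from compound 3 to compound 4 (0.52 log units; beyond the scatter). For compound 4 the estimate is 20 uM, with an expected range of 4 uM to 100 uM.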

Compound 4, concentration for half-maximal effect: 6 uM
For compound 4 the middle estimate is 3.3-fold (0.52 log units) above the measured one, within the range that was stated.
By their numbers in this assay, from the lowest: compound 1; then compounds 2 and 4 (each within the scatter of the next); then compound 3.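

In this assay, ((((methylsulfanyl)methyl)carbonyl)amino)methyl on this aromatic carbon gives an 11-fold lower number from compound 3 to compound 4 (1.04 log units; beyond the scatter), although the leaving and entering groups count the same hydrogen-bond donors and acceptors, so those counts do not separate the two. A group with no ring and a different atom set gives a 1.3-fold higher number from compound 2 to compound 4 (0.10 log units; within the scatter), while a 5.0-fold higher number from compound 1 to compound 4 (0.70 log units; beyond the scatter) leaves the lowest number unchanged. No available data give a reason for these steps. Open, from the compounds shown here alone, is how a carboxylic acid or a longer chain at this carbon would read in this assay.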